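Naphthyl for Nitrophenyl on a Thiazole Growth Inhibitor

The source may hold more compounds than are shown below. What is called first, only, known or untested is meant among the compounds shown, and "the series" means these compounds.

Of the compounds shown here, three share a core and have been tested in a functional assay on HL-60 cells (Homo sapiens) for inhibition, read by trypan blue exclusion, with a stated time of 72 h; a higher number here means a weaker inhibitor of growth, a lower number a stronger inhibitor of growth. Compound 1 `C=C(C)C(=O)c1ccc(OCc2nc(-c3ccccc3)cs2)cc1C` gives 4700 nM in this assay, and compound 2 `C=C(C)C(=O)c1ccc(OCc2nc(-c3ccc(C(F)(F)F)cc3)cs2)c(C)c1C` gives 3100 nM. Compound 3 `C=C(CC)C(=O)c1ccc(OCc2nc(-c3ccc([N+](=O)[O-])cc3)cs2)cc1Cl` stands at the lowest of the three numbers, with 800 nM in this assay; its nearest neighbour is compound 2, whose number is higher by a margin beyond the usual scatter, and compound 1 lies further still.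

Compound 4 `C=C(CC)C(=O)c1ccc(OCc2nc(-c3ccc4ccccc4c3)cs2)cc1Cl` has not yet been measured. It differs from compound 3 in one place: naphthalen-2-yl in place of 4-nitrophenyl on an aromatic carbon. Going by the values given here, no measured pair shows this particular exchange, so the direction of the step cannot be read from the data. On the numbers shown for compound 3, the value of compound 4 in this assay is expected to be 1200 nM, within a range from 400 nM to 3500 nM. The step this estimate means, from compound 3 to compound 4, is expected to be a 1.5-fold higher number from compound 3 to compound 4 (0.18 log units; within the scatter), a modest weakening that may still sit close to the scatter.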

Compound 4, concentration for 50% growth inhibition: 900 nM
Estimate against measurement, compound 4: 1.3-fold (0.12 log units) above; measured number inside the range.
By their numbers in this assay, from the lowest: compounds 3 and 4 (each within the scatter of the next); then compounds 2 and 1 (each within the scatter of the next).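

In this assay the exchange gives a 1.1-fold higher number from compound 3 to compound 4 (0.05 log units; within the scatter) and is the only change in a single place among the compounds shown. On this core, the position on the aromatic carbon next to the ring nitrogen therefore holds either 4-nitrophenyl, which has nitrogen and oxygen atoms and a double bond outside the aromatic ring, or naphthalen-2-yl, which is all carbon and has a second aromatic ring, with no difference that can be told from scatter. Nothing measured here explains why the two groups read alike.

Going by these compounds, whether an amine or a carboxylic acid on the phenyl ring, or a saturated ring such as cyclohexyl, would also leave the number in place remains open. So does whether this exchange would read the same on the cores of compound 1 and compound 2, which differ from compound 3 in more than one place.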